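A few compounds are considered here, and "the series" means these few. Any claim that something is new, unique, unknown or untested is made for them only; others in the source may bear on it.

Measured so far in a toxicity assay on HeLa cells (Homo sapiens) for cytotoxicity; a higher number here means that more compound is tolerated, a lower number that less compound is tolerated:
compound 1 `COc1nc(C2CCCCC2)ccc1[C@@H](c1ccccc1)[C@@](O)(CCN(C)C)c1cccc2ccccc12`, 57.7 ug/mL;
compound 2 `COc1nc(-c2ccc(Cl)c(F)c2)ccc1[C@@H](c1ccccc1)[C@@](O)(CCN(C)C)c1cccc2ccccc12`, > 64 ug/mL.

For compound 2 the figure in this assay is a limit, not a number. Among the compounds with values here, it is the one value among the two that sits at the limit of > 64 ug/mL in this assay, at which 1 of the 2 values shown sits. Compound 2 therefore cannot be placed more closely than that on the numbers shown. The one measured step, an at least 1.1-fold higher number from compound 1 to compound 2 (0.04 log units; that floor lies within the scatter), carries a floor that lies within the scatter, so no change beyond the scatter is shown by the pair.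

Compound 3 `COc1nc(-c2ccc(C#N)cc2)ccc1[C@@H](c1ccccc1)[C@@](O)(CCN(C)C)c1cccc2ccccc12` is next. It differs from compound 2 in one place: 4-cyanophenyl in place of 4-chloro-3-fluorophenyl on an aromatic carbon. Within the data shown here, no measured step exchanges one aryl group for another at that position; the only step that bears on it, an at least 1.1-fold higher number from compound 1 to compound 2 (0.04 log units; that floor lies within the scatter), stays within the scatter and ends at a limit. A step that does not go beyond the scatter is therefore expected from compound 2 to compound 3, an at least 1.1-fold lower number from compound 2 to compound 3 (0.04 log units; that floor lies within the scatter), with a real chance that compound 3 also reports only a limit in this assay. The expected value for compound 3 is 58 ug/mL, with a range from 32 ug/mL to 64 ug/mL.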

Compound 3, half-maximal cytotoxic concentration: > 64 ug/mL
Compound 3 gave a limit, no number; the forecaster's own chance of this, stated with the estimate: 50%; at least 1.1-fold (0.04 log units) between middle value and limit.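

In this assay, the aromatic carbon next to the ring nitrogen now carries two different aryl groups, 4-chloro-3-fluorophenyl and 4-cyanophenyl, and the compounds bearing them end at the same reading: the limit of > 64 ug/mL in this assay, at which 2 of the 3 values shown sit.

The step between compound 2 and compound 3 cannot be read, and no order of these two aryl groups can be stated. Exchanging cyclohexyl for 4-cyanophenyl gives an at least 1.1-fold higher number from compound 1 to compound 3 (0.04 log units; that floor lies within the scatter), so the second aryl group, like the first, shows no change from cyclohexyl beyond the scatter, now with a nitrile in the group entering this position.

From the compounds shown here alone, how far compound 2 and compound 3 lie past the limit remains open, and with it whether either truly differs from compound 1 by more than the scatter. Also open, going by these compounds, is whether an amine or a carboxylic acid at this carbon, in place of the aryl groups, would give a number in this assay rather than a limit.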